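The compounds below may be only part of what the source reports. "The series", "measured", "known", "first", "only" and "open" are said of these compounds alone.

Among the compounds with values here, in a functional assay on KG-1 cells (Homo sapiens) for cytotoxicity, read by luminescence and CellTiter-Glo, with a stated time of 3 days (on this read-out higher numbers stand for weaker inhibition and lower numbers for stronger inhibition), compound 1 (`O=C(Nc1ccc(C(F)(F)F)cc1)c1cc(Cl)ccc1O`) gives 740 nM, the lower of the two numbers so far, and compound 2 (`O=C(Nc1ccc(C(F)(F)F)cc1)c1cc(F)ccc1O`) gives 1700 nM. Compound 3 (`O=C(Nc1ccc(C(F)(F)F)cc1)c1cc(Cl)c(-c2ccccc2)cc1O`) differs from compound 1 at one place, with phenyl in place of hydrogen on an aromatic carbon. Within the data shown here, the only measured step, a 2.3-fold higher number from compound 1 to compound 2 (0.36 log units; beyond the scatter), is modest and swaps fluoro for chloro, so it is a weak guide. Among the measured compounds shown here, no measured compound tests an added phenyl, so the direction stays open and no step beyond the scatter is expected. The expected step is a 1.1-fold lower number from compound 1 to compound 3 (0.06 log units; within the scatter). For compound 3 the estimated value is 650 nM, with an expected range of 170 nM to 2500 nM.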

Compound 3, half-maximal inhibitory concentration: 770 nM
Estimate against measurement, compound 3: 1.2-fold (0.07 log units) below; the measured number falls inside the stated range.
By their numbers in this assay, from the lowest: compounds 1 and 3 (each within the scatter of the next); then compound 2.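

In this assay, phenyl in place of hydrogen on the aromatic carbon ortho to the chloro group gives a 1.0-fold higher number from compound 1 to compound 3 (0.02 log units; within the scatter), so this position takes a six-membered aromatic ring of carbon only with no step beyond the scatter. This is the first change shown at this position, and it is a large one at 6 heavy atoms. No measurement at hand bears on why the number holds here.

Still open, from the compounds shown here alone, is whether an amine, a carboxylic acid or a cyclohexyl group at this position would hold the number as well. Also open, going by these compounds, is whether phenyl would behave the same way with fluoro in place of chloro.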